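Trimethylpiperazine change tried on a second core

The source may hold more compounds than are shown below. What is called first, only, known or untested is meant among the compounds shown, and "the series" means these compounds.

Measured so far:
Compound 1, `COc1cc2c(cc1N1CCN(C)CC1)N(C(=O)c1ccc(-c3cccc(C)n3)c3ccccc13)CC2`: 25.1 nM
Compound 2, `COc1cc2c(cc1N1C[C@@H](C)N(C)[C@@H](C)C1)N(C(=O)c1ccc(-c3cccc(C)n3)c3ccccc13)CC2`: 100 nM
Compound 3, `COc1cc2c(cc1N1CCN(C)CC1)N(C(=O)Nc1cccc(Cl)c1Cl)CC2`: 12.6 nM

All three numbers come from an assay on isolated protein for binding affinity to 5-hydroxytryptamine receptor 1D (Homo sapiens); on this read-out lower numbers stand for stronger inhibition and higher numbers for weaker inhibition. Compound 1 and compound 2 share one core and differ in a single place: 3,4,5-trimethylpiperazin-1-yl in place of 4-methylpiperazin-1-yl on an aromatic carbon. That change produced a 4.0-fold higher number from compound 1 to compound 2 (0.60 log units; beyond the scatter). Compound 3 is built on a different core; how its core differs from that of compound 1 is not broken down here. Among the three measured compounds, compound 3 has the lowest number, lying within the scatter of compound 1 and beyond the scatter from compound 2.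

Compound 4, `COc1cc2c(cc1N1C[C@@H](C)N(C)[C@@H](C)C1)N(C(=O)Nc1cccc(Cl)c1Cl)CC2`, has not yet been measured. It is related to compound 3 by the same change, in the same surroundings, as the one already seen: 3,4,5-trimethylpiperazin-1-yl in place of 4-methylpiperazin-1-yl on an aromatic carbon. For the measured compounds named here, for compound 4 a step of a 4.0-fold higher number from compound 3 to compound 4 (0.60 log units; beyond the scatter) is expected, because a 4.0-fold higher number from compound 1 to compound 2 (0.60 log units; beyond the scatter) was found for this change on the other core, and only that one earlier step is available to rest on. Compound 4 is therefore estimated at 50 nM, with a likely range from 20 nM to 125 nM.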

Compound 4, inhibition constant: 79.4 nM
Compound 4: middle estimate off by 1.6-fold (0.20 log units), on the low side, and the stated range covers the measured number.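

On the core of compound 3, putting 3,4,5-trimethylpiperazin-1-yl in place of 4-methylpiperazin-1-yl gave, in this assay, a 6.3-fold higher number from compound 3 to compound 4 (0.80 log units; beyond the scatter). Set beside the earlier step on the core of compound 1, the new step points the same way and the two do not differ in size beyond what repeated measurements would produce: the same change on two cores in this assay, a 4.0-fold higher number (0.60 log units; beyond the scatter) from compound 1 to compound 2 and a 6.3-fold higher number (0.80 log units; beyond the scatter) from compound 3 to compound 4, 1.6-fold (0.20 log units) apart, within the scatter of two such steps This shows that, on these two cores, the change weakened binding to a similar degree, so the step seen on one core was a fair guide to the other, but two cores are too few to show that it would hold on a third or to explain why the number rises.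

What the compounds shown leave open is which part of the added bulk matters, since a piperazine with just one extra methyl group, or a morpholine in place of the piperazine, would help to separate these possibilities. As far as these compounds go, it also remains open whether the opposite arrangement of the two defined stereocentres would give a similar step.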